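A Fluorophenyl in Place of a Chlorophenyl

A few compounds are considered here, and "the series" means these few. Any claim that something is new, unique, unknown or untested is made for them only; others in the source may bear on it.

Of the compounds shown here, three sharing one core have been measured in an ADME assay on HEL cells (Homo sapiens) for cytotoxicity; a lower number here means that less compound is tolerated, a higher number that more compound is tolerated. Compound 1 `O=C(COc1cccc2ccccc12)N/N=C/c1cccc(O)c1` gives 100 ug/mL. Compound 2 `O=C(COc1cccc2ccccc12)N/N=C/c1cccc(Br)c1` gives 100 ug/mL, and compound 3 `O=C(COc1cccc2ccccc12)N/N=C/c1ccccc1Cl` gives 100 ug/mL. Compound 3 thus stands level with compounds 1 and 2: the step of no change at the digits printed from compound 1 to compound 3 (within the scatter) and the step of no change at the digits printed from compound 2 to compound 3 (within the scatter) both lie within the scatter, as does the step of no change at the digits printed from compound 1 to compound 2 (within the scatter).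

Compound 4 `O=C(COc1cccc2ccccc12)N/N=C/c1ccc(F)cc1` differs from compound 3 in one place: 4-fluorophenyl in place of 2-chlorophenyl on a carbon with a double bond to nitrogen. The measured steps that bear on this are those that exchange one aromatic group for another on the carbon with a double bond to nitrogen, no change at the digits printed from compound 1 to compound 3 (within the scatter) and no change at the digits printed from compound 2 to compound 3 (within the scatter), and neither moved the read-out beyond the scatter. An exchange of one phenyl group for another on that carbon is therefore expected to leave this assay where it is, a step of no change at the digits printed from compound 3 to compound 4 (within the scatter). For compound 4 the estimated minimum cytotoxic concentration is 100 ug/mL, within a range from 50 ug/mL to 200 ug/mL.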

Compound 4, minimum cytotoxic concentration: 100 ug/mL
Beside the measured number, compound 4's estimate shows no gap at the digits printed; the range from low to high includes it.
By their numbers in this assay, from the lowest: compounds 1, 2, 3 and 4 (each within the scatter of the next).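

With 4-fluorophenyl on the carbon with a double bond to nitrogen, this assay shows no change at the digits printed from compound 3 to compound 4 (within the scatter) and no change at the digits printed from compound 2 to compound 4 (within the scatter) and also no change at the digits printed from compound 1 to compound 4 (within the scatter) in this set. The four compounds now carry 3-hydroxyphenyl, 3-bromophenyl, 2-chlorophenyl or 4-fluorophenyl at this one place, and none stands apart from the others, so fluorine in the 4-position of the ring fits the same flat picture as the earlier groups. Nothing here gives a measured reason for this sameness.

All four groups at this place are substituted phenyl rings, so these compounds cannot tell whether a phenyl ring bearing an amine or a carboxylic acid would read differently. Nor do they show what a longer chain in place of the ring would do, or whether changes to the shared core would matter more.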